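The source may report more compounds than this note shows. Statements on the series, on what has been measured and on what is new or still open speak of the compounds shown alone.

Measured compounds:
compound 1 `CCn1c(C(=O)NCCN)ccc1C(CC)(CC)c1ccc(OCC(=O)C(C)(C)C)c(C)c1` — 120 nM
compound 2 `CCn1c(C(=O)NCCN)ccc1C(CC)(CC)c1ccc(OCC(O)C(C)(C)C)c(C)c1` — 10 nM
compound 3 `CC[C@@H](C)[C@H](NC(=O)c1ccc(C(CC)(CC)c2ccc(OCC(O)C(C)(C)C)c(C)c2)n1CC)C(=O)O` — 2.3 nM

In an assay on HL-60 cells for agonist activity at vitamin D3 receptor (Homo sapiens), read by microscopy, with a stated time of 96 h (on this read-out higher numbers stand for an effect only at larger amounts of compound and lower numbers for an effect already at smaller amounts), compound 1 gives the highest of the three numbers; compound 2 lies a 12-fold lower number from compound 1 to compound 2 (1.08 log units; beyond the scatter) away, and compound 3 further still. Compound 4 `CCn1c(C(=O)Nc2ccc(OC(F)(F)F)cc2)ccc1C(CC)(CC)c1ccc(OCC(=O)C(C)(C)C)c(C)c1` departs from compound 1 at the amide-type nitrogen: 4-(trifluoromethoxy)phenyl in place of 2-aminoethyl on an amide-type nitrogen. Among the measured compounds shown here, only one measured step touches that nitrogen, a 4.3-fold lower number from compound 2 to compound 3 (0.64 log units; beyond the scatter), and it exchanged the 2-aminoethyl for a 1-carboxy-2-methylbutyl rather than an aromatic group, so it speaks only loosely to compound 4. The data give no case of an aryl group on that nitrogen. Compound 4 is therefore expected to stay near compound 1 in this assay, with a slight rise as the more likely side, a step of a 1.7-fold higher number from compound 1 to compound 4 (0.22 log units; within the scatter). The estimate for compound 4 is 200 nM, between 50 nM and 800 nM.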

Compound 4, half-maximal effective concentration: > 50000 nM
Compound 4 was reported as a limit; the forecaster's own chance of this, stated with the estimate: 15%; middle value at least 250-fold (2.39 log units) away from the limit.
By their numbers in this assay, from the lowest: compound 3; then compound 2; then compound 1. At a limit, above all of these: compound 4.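

In this assay, among the compounds shown here, the group on the amide-type nitrogen proves able to move the number far more than the earlier compounds showed: an at least 410-fold higher number from compound 1 to compound 4 (2.61 log units; beyond the scatter). For the compounds shown here, the only earlier change at this nitrogen, to 1-carboxy-2-methylbutyl, went the other way and by less, a 4.3-fold lower number from compound 2 to compound 3 (0.64 log units; beyond the scatter). Compound 4 is known here only as a limit: the limit of > 50000 nM in this assay, at which 1 of the 4 values shown sits.

From the compounds shown here alone, it remains open whether a plain phenyl, or a phenyl carrying an amine or a carboxylic acid, on that nitrogen would behave like 4-(trifluoromethoxy)phenyl. Going by these compounds, it is also open whether the 1-hydroxy-2,2-dimethylpropyl of compound 2 would alter the outcome with this aryl group.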